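Removing a Methyl From a Spirocyclic Pyrazolone Series

A few compounds are considered here, and "the series" means these few. Any claim that something is new, unique, unknown or untested is made for them only; others in the source may bear on it.

Measured compounds:
compound 1 `CC1=NN(c2ccc(Br)cc2)C(=O)C12C=CC(=O)C=C2c1ccccc1` — > 100000 nM
compound 2 `CC1=NN(c2ccccc2)C(=O)C12C=CC(=O)C=C2c1ccccc1` — 27400 nM
compound 3 `CC1=NN(c2ccc(Cl)cc2)C(=O)C12C=CC(=O)C=C2c1cccc(C)c1` — 26900 nM

In a functional assay on MDA-MB-231 cells (Homo sapiens) for antiproliferative activity, read by CCK-8 assay, with a stated time of 72 h (on this read-out lower numbers stand for stronger inhibition and higher numbers for weaker inhibition), compound 1 gives > 100000 nM, which is a limit of the assay rather than a number (the limit of > 100000 nM in this assay, at which 1 of the 3 values shown sits). In this assay compound 2 gives 27400 nM, and compound 3 gives 26900 nM. Compound 3 thus holds the lowest of the two plain numbers, but its gap to compound 2 lies within the scatter, so no order between the two can be claimed. Among the measured compounds shown here, the one measured step, an at least 3.6-fold lower number from compound 1 to compound 2 (0.56 log units; beyond the scatter), concerns hydrogen in place of bromo on an aromatic carbon and is at least modest.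

Compound 4 `CC1=NN(c2ccc(Cl)cc2)C(=O)C12C=CC(=O)C=C2c1ccccc1` differs from compound 3 by hydrogen in place of methyl on an aromatic carbon. For the measured compounds named here, no measured step concerns a methyl group; the step from compound 1 to compound 2 bears on a different change and offers no direct guide. The expected step is therefore small, a 1.1-fold higher number from compound 3 to compound 4 (0.05 log units; within the scatter), within the scatter. Compound 4 is estimated at 30000 nM, with a range from 12000 nM to 80000 nM.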

Compound 4, half-maximal inhibitory concentration: > 100000 nM
Compound 4 gave a limit, no number (the forecaster's own chance of this, stated with the estimate: 15%); at least 3.3-fold (0.52 log units) between middle value and limit.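

In this assay, among the compounds shown here, the change from 3-methylphenyl to phenyl gives an at least 3.7-fold higher number from compound 3 to compound 4 (0.57 log units; beyond the scatter), so a single methyl on an aromatic carbon, a change no earlier step touched, proves able to move the read-out beyond the scatter. Chloro in place of hydrogen on an aromatic carbon gives an at least 3.6-fold higher number from compound 2 to compound 4 (0.56 log units; beyond the scatter), which shows with chloro the same direction that an at least 3.6-fold lower number from compound 1 to compound 2 (0.56 log units; beyond the scatter) shows, read in reverse, for bromo. The reading of compound 4 is a limit of the assay, not a number.

Going by these compounds, whether the methyl has a like effect without the chloro stays open, as does whether a methoxy or an ethyl group in its place would do the same. The step between compound 1 and compound 4 cannot be read, because both sit at the same limit: the limit of > 100000 nM in this assay, at which 2 of the 4 values shown sit.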